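A few compounds are considered here, and "the series" means these few. Any claim that something is new, unique, unknown or untested is made for them only; others in the source may bear on it.

In a functional assay on MDA-MB-435 cells (Homo sapiens) for cytotoxicity, read by MTT assay, with a stated time of 72 h (on this read-out lower numbers stand for stronger inhibition and higher numbers for weaker inhibition), compound 1 `Nc1ccc(Nc2c(C(=O)NCc3ccc(F)cc3)nc(Br)c3cccnc23)cc1` gives 7000 nM. Compound 2 `N[C@H]1CC[C@H](Nc2c(C(=O)NCc3ccc(F)cc3)nc(Br)c3cccnc23)CC1` gives 6000 nM in this assay, and compound 3 `CN(C)CCCNc1c(C(=O)NCc2ccc(F)cc2)nc(Br)c2cccnc12` gives 7000 nM in this assay. Compound 3 stands level with compound 1 and within the scatter of compound 2: the step of no change at the digits printed from compound 1 to compound 3 (within the scatter) and the step of a 1.2-fold higher number from compound 2 to compound 3 (0.07 log units; within the scatter) both fall inside the scatter, as does a 1.2-fold lower number from compound 1 to compound 2 (0.07 log units; within the scatter). Compound 4 `O=C(NCc1ccc(F)cc1)c1nc(Br)c2cccnc2c1NCCO` differs from compound 3 by hydroxy in place of (dimethylamino)methyl on a saturated chain carbon, two bonds along the chain from a nitrogen on an aromatic ring. The three measured steps all exchange the group on the same nitrogen on an aromatic ring and none moves the number beyond the scatter, so for this further exchange no shift beyond the scatter is expected in this assay. The estimate for compound 4 in this assay is 7000 nM, with a range from 3500 nM to 14000 nM. The expected step is no change at the digits printed from compound 3 to compound 4 (within the scatter).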

Compound 4, half-maximal inhibitory concentration: > 20000 nM
Compound 4 ended at the assay's limit; the forecaster's own chance of this, stated with the estimate: 10%; middle value at least 2.8-fold (0.45 log units) from the limit.
By their numbers in this assay, from the lowest: compounds 2, 1 and 3 (each within the scatter of the next). At a limit, above all of these: compound 4.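

In this assay compound 4 gives a limit of the assay, not a number: the limit of > 20000 nM in this assay, at which 1 of the 4 values shown sits.

The group on this nitrogen, which left the number within the scatter across the earlier exchanges, now matters: an at least 2.8-fold higher number from compound 3 to compound 4 (0.45 log units; beyond the scatter), an at least 3.3-fold higher number from compound 2 to compound 4 (0.52 log units; beyond the scatter) and an at least 2.8-fold higher number from compound 1 to compound 4 (0.45 log units; beyond the scatter). Of the four groups shown, 4-aminophenyl, 4-aminocyclohexyl and 3-(dimethylamino)propyl all carry an amine, and only 2-hydroxyethyl, which does not, lies beyond the scatter.

As far as these compounds go, whether the amine or the chain length counts remains open, since hydroxy replaces (dimethylamino)methyl and the chain shortens with it. A 3-hydroxypropyl or 2-(dimethylamino)ethyl group on the same nitrogen would separate the two.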